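Iodo in place of furan-2-yl: working notes

A few compounds are considered here, and "the series" means these few. Any claim that something is new, unique, unknown or untested is made for them only; others in the source may bear on it.

Measured so far in a functional assay on K562 cells (Homo sapiens), read by MTT assay, with a stated time of 72 h; on this read-out higher numbers stand for weaker inhibition and lower numbers for stronger inhibition
compound 1 (`CNc1ncnc2c1c(-c1ccco1)cn2[C@@H]1O[C@H](CO)[C@@H](O)[C@H]1O`): 15100 nM
compound 2 (`Cc1ncnc2c1c(-c1cc3ccccc3o1)cn2[C@@H]1O[C@H](CO)[C@@H](O)[C@H]1O`): > 20000 nM (a limit of the assay)
compound 3 (`Cc1nc(N)c2c(-c3cc4ccccc4o3)cn([C@@H]3O[C@H](CO)[C@@H](O)[C@H]3O)c2n1`): 4990 nM

Compound 1 holds the higher of the two actual numbers, and compound 3 lies lower at 4990 nM by a gap beyond the usual scatter. Compound 2 gives only a limit. Compound 4 (`CNc1ncnc2c1c(I)cn2[C@@H]1O[C@H](CO)[C@@H](O)[C@H]1O`) carries iodo in place of furan-2-yl on an aromatic carbon. For the measured compounds named here, no measured step isolates this change, so the expectation is loose. Compound 3 at 4990 nM shows that numbers lower than that of compound 1 occur here, and a lower number beyond the scatter is expected in this assay for compound 4. The expected change is a 5.0-fold lower number from compound 1 to compound 4 (0.70 log units; beyond the scatter) as an estimate only. For compound 4 the estimated value is 3000 nM with an expected range from 400 nM to 18000 nM in the coming measurement.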

Compound 4, half-maximal inhibitory concentration: > 20000 nM
Compound 4: a limit, no number; the forecaster's own chance of this, stated with the estimate: 12%; at least 6.6-fold (0.82 log units) between middle value and limit.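

In this assay compound 4 gives > 20000 nM, which is a limit of the assay and not a number. From the compounds shown here alone, on this aromatic carbon, iodo in place of furan-2-yl gives no lower number, only an at least 1.3-fold higher number from compound 1 to compound 4 (0.12 log units; that floor lies within the scatter), so the true size of the change stays unknown. The ceiling of the assay restricts what this position can show: the limit of > 20000 nM in this assay, at which 2 of the 4 values shown sit.

Going by these compounds, what an amine or a carboxylic acid on this aromatic carbon would give in this assay stays open. On these data alone, whether any group here gives a number clearly lower than that of compound 1 also stays open.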